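The source may hold more compounds than are shown below. What is called first, only, known or untested is meant among the compounds shown, and "the series" means these compounds.

Among the measured compounds shown here, in an ADME assay on a cell-free system (plasma, Rattus norvegicus, strain Sprague-Dawley) for metabolic stability, read by LC-MS, with a stated time of 120 min, tested at 1 uM (a lower number here means that less of the compound is left, a higher number that more of the compound is left), compound 3 `CC#CCn1c(N2CCC[C@@H](N)C2)nc2c1c(=O)n(Cc1ccc(Cl)cc1C(=O)O)c(=O)n2C` stands highest of the three compounds measured so far, at 102%. Compound 1 `CC#CCn1c(N2CCC[C@@H](N)C2)nc2c1c(=O)n(Cc1ccc(Br)cc1C(=O)OC)c(=O)n2C` gives 54.2%, and compound 2 `CC#CCn1c(N2CCC[C@@H](N)C2)nc2c1c(=O)n(Cc1ccc(Br)cc1C(=O)OCC)c(=O)n2C` gives 62.2%. Compound 4 `CC#CCn1c(N2CCC[C@@H](N)C2)nc2c1c(=O)n(Cc1ccc(Cl)cc1C(=O)OC)c(=O)n2C` has not been measured yet. It differs from compound 3 by one change, methyl in place of hydrogen on an oxygen next to a carbonyl group, which turns carboxy into methoxycarbonyl.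

Two measured steps run the opposite way and were both large: a number 47.8 percentage points higher from compound 1 to compound 3 (beyond the scatter) and a number 39.8 percentage points higher from compound 2 to compound 3 (beyond the scatter). Each also exchanges bromo for chloro, so neither shows the effect of the methyl alone. Compound 1 is the closest guide, since it carries 4-bromo-2-(methoxycarbonyl)phenyl where compound 4 carries 4-chloro-2-(methoxycarbonyl)phenyl. The remaining step, a number 8 percentage points higher from compound 1 to compound 2 (within the scatter), lies within the scatter. A large downward step is therefore expected, roughly the reverse of the two large steps. The expected step is a number 47 percentage points lower from compound 3 to compound 4 (beyond the scatter). Compound 4 is estimated at 55%, with an expected range from 40% to 70%.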

Compound 4, percent of the compound remaining: 65.2%
Estimate against measurement, compound 4: 10.2 percentage points below, within the range that was stated.
By their numbers in this assay, from the lowest: compounds 1, 2 and 4 (each within the scatter of the next, the first and the last beyond it); then compound 3.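

Among the compounds shown here, with the halogen held at chloro, methyl on the oxygen of the carboxy group is the only change in a number 36.8 percentage points lower from compound 3 to compound 4 (beyond the scatter), so in this assay methoxycarbonyl alone leaves clearly less compound than carboxy. Chloro in place of bromo on the aromatic carbon gives a smaller effect, a number 11 percentage points higher from compound 1 to compound 4 (beyond the scatter), so most of the large rise towards compound 3 goes with the carboxy group rather than the halogen. The step of a number 3 percentage points higher from compound 2 to compound 4 (within the scatter) changes both the halogen and the ester chain, so its two parts cannot be separated.

Nothing shown gives a measured reason for these differences. Going by these compounds, it remains open how an amide or a propyl ester would behave in place of methoxycarbonyl, and whether the carboxylic acid with bromo would match compound 3.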